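The source may hold more compounds than are shown below. What is called first, only, known or untested is meant among the compounds shown, and "the series" means these compounds.

Compound 2 `Cc1cc(C(=O)Nc2ccccn2)nn1Cc1cc(Cl)ccc1OCc1ccccc1` gives 126 nM in an assay on CHO-K1 cells for displacement of a labelled ligand from prostaglandin E2 receptor EP1 subtype (Homo sapiens) (a higher number here means a weaker inhibitor, a lower number a stronger inhibitor), level with compound 1 `Cc1cc(C(N)=O)nn1Cc1cc(Cl)ccc1OCc1ccccc1` at 126 nM; together these are the highest numbers of the three. Compound 3 `Cc1cc(NC(=O)C(C)C)nn1Cc1cc(Cl)ccc1OCc1ccccc1` sits at 25.1 nM, reached through a 5.0-fold lower number from compound 1 to compound 3 (0.70 log units; beyond the scatter) and a 5.0-fold lower number from compound 2 to compound 3 (0.70 log units; beyond the scatter). The step of no change at the digits printed from compound 1 to compound 2 (within the scatter) shows that the pyridin-2-yl on the amide-type nitrogen made no difference.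

Compound 4 `Cc1cc(NC(=O)O[C@H]2CCOC2)nn1Cc1cc(Cl)ccc1OCc1ccccc1` differs from compound 2 by (((oxolan-3-yl)oxy)carbonyl)amino in place of (pyridin-2-yl)carbamoyl on an aromatic carbon. As in compound 3, the aromatic carbon now carries an amino group bearing a carbonyl instead of a carbamoyl, so the bearing measurement is a 5.0-fold lower number from compound 2 to compound 3 (0.70 log units; beyond the scatter). Because a 5.0-fold lower number from compound 2 to compound 3 (0.70 log units; beyond the scatter) was modest and the entering group is (((oxolan-3-yl)oxy)carbonyl)amino rather than (isopropylcarbonyl)amino, a somewhat smaller drop is expected, a 2.8-fold lower number from compound 2 to compound 4 (0.45 log units; beyond the scatter). Compound 4 is expected at 45 nM, range 15 nM to 130 nM.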

Compound 4, half-maximal inhibitory concentration: 79.4 nM
For compound 4 the middle estimate is 1.8-fold (0.25 log units) below the measured one, within the range that was stated.
By their numbers in this assay, from the lowest: compound 3; then compounds 4, 1 and 2 (each within the scatter of the next).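

An amino group bearing a carbonyl on this aromatic carbon does not alone secure the lower number of compound 3: with (oxolan-3-yl)oxy in place of isopropyl on the carbonyl carbon, there is a 3.2-fold higher number from compound 3 to compound 4 (0.50 log units; beyond the scatter) in this assay. Compound 4 is not separated from the carbamoyl compounds, with a 1.6-fold lower number from compound 2 to compound 4 (0.20 log units; within the scatter) and a 1.6-fold lower number from compound 1 to compound 4 (0.20 log units; within the scatter), so the group on that carbonyl carbon counts here as well as the link. Nothing available explains the gap between isopropyl and (oxolan-3-yl)oxy.

Open, as far as these compounds go, is where a dimethylamine or a longer alkyl chain on that carbonyl carbon would fall relative to compound 3 and compound 4. Also open, from the compounds shown here alone, is whether the opposite configuration of the oxolan-3-yl stereocentre would read the same.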